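Cyclopropylmethyl in place of the ester side chain

A few compounds are considered here, and "the series" means these few. Any claim that something is new, unique, unknown or untested is made for them only; others in the source may bear on it.

In a functional assay on DU-145 cells (Homo sapiens) for inhibition, read by trypan blue exclusion, with a stated time of 72 h (on this read-out lower numbers stand for stronger inhibition and higher numbers for weaker inhibition), compound 1 (`COC(=O)Cn1c(=O)c(S(=O)(=O)c2ccc(F)cc2F)cc2cnc(Nc3ccc4[nH]ccc4c3)nc21`) gives 10000 nM and shares the highest number of the three measured compounds with compound 2 (`Cc1ccc(S(=O)(=O)c2cc3cnc(Nc4cccc5cccnc45)nc3n(C)c2=O)cc1`) at 10000 nM in the same read-out. Compound 3 (`Cn1c(=O)c(S(=O)(=O)c2ccc(F)cc2)cc2cnc(Nc3cccc4[nH]ccc34)nc21`) gives a clearly lower 750 nM (beyond the scatter of compound 1). Compound 4 (`O=c1c(S(=O)(=O)c2ccc(F)cc2F)cc2cnc(Nc3ccc4[nH]ccc4c3)nc2n1CC1CC1`) carries cyclopropyl in place of methoxycarbonyl on a saturated chain carbon bound to an aromatic nitrogen. Among the measured compounds shown here, no measured pair isolates this change, so the expectation in this assay is only a modest fall in the number, possibly not beyond the scatter. The expected step is a 2.0-fold lower number from compound 1 to compound 4 (0.30 log units; within the scatter) (an estimate, pointing lower). For compound 4 the estimated value is 5000 nM (estimated range 1000 nM to 12000 nM).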

Compound 4, half-maximal inhibitory concentration: 1000 nM
The estimate for compound 4 lay 5.0-fold (0.70 log units) above the measured number, and the stated range covers the measured number.
By their numbers in this assay, from the lowest: compounds 3 and 4 (each within the scatter of the next); then compounds 1 and 2 (each within the scatter of the next).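

Cyclopropyl in place of methoxycarbonyl on a saturated chain carbon bound to an aromatic nitrogen gives a 10-fold lower number from compound 1 to compound 4 (1.00 log units; beyond the scatter) in this assay, the first single-place read on this side chain. This position therefore moves the number beyond the scatter, and the ester is not required for inhibition on this read-out. Nothing available here explains the step.

On these data alone, whether the step follows from losing the ester or from gaining the three-membered ring stays open. A carboxylic acid, an amine or a longer chain in place of cyclopropyl would help separate the two.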